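A few compounds are considered here, and "the series" means these few. Any claim that something is new, unique, unknown or untested is made for them only; others in the source may bear on it.

Of the compounds shown here, three built on one shared core have been tested in an assay on isolated protein for inhibition of malate dehydrogenase, mitochondrial (Sus scrofa), with stated times of 45 min and 30 min; a lower number here means a stronger inhibitor, a higher number a weaker inhibitor. Compound 1 `O=S(=O)(Nc1ccc(-c2nc3ccccc3o2)cc1)c1cccc(O)c1` carries a 3-hydroxyphenyl on the sulfonyl sulfur. In this assay compound 1 gives only a limit, > 63000 nM. Compound 2 `O=S(=O)(Nc1ccc(-c2nc3ccccc3o2)cc1)c1ccccc1F` carries a 2-fluorophenyl there instead. In this assay compound 2 likewise gives only a limit, > 63000 nM. Compound 3 `COc1ccccc1S(=O)(=O)Nc1ccc(-c2nc3ccccc3o2)cc1` carries a 2-methoxyphenyl. In this assay compound 3 again gives only a limit, > 63000 nM.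

Since every value is a limit, none of the steps between these compounds can be read: a step that the two limits leave unreadable from compound 1 to compound 2, a step that the two limits leave unreadable from compound 1 to compound 3 and a step that the two limits leave unreadable from compound 2 to compound 3. Compound 3 thus stands at the same limit as compound 1 and compound 2, as the limit of > 63000 nM in this assay, at which 3 of the 3 values shown sit, shows.

Compound 4 `COc1cccc(S(=O)(=O)Nc2ccc(-c3nc4ccccc4o3)cc2)c1` has not yet been measured. It differs from compound 3 only in the position of the methoxy group on the ring at the sulfonyl sulfur: 3-methoxyphenyl in place of 2-methoxyphenyl on a sulfonyl sulfur. The three measured steps bear on this change only in that swapping substituents on that ring has so far never produced a readable value. No step beyond the scatter is therefore expected, and the step from compound 3 to compound 4 is estimated as a step that the limit leaves unreadable from compound 3 to compound 4. Compound 4 is expected to give 100000 nM in this assay, within a range from 30000 nM to 300000 nM.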

Compound 4, half-maximal inhibitory concentration: > 63000 nM
Compound 4 was reported as a limit (the forecaster's own chance of this, stated with the estimate: 85%); the middle value lies beyond the limit too.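

Compound 4 also gives only a limit, so the steps to it from compound 1, compound 2 and compound 3 cannot be read: the limit of > 63000 nM in this assay, at which 4 of the 4 values shown sit. The compounds shown leave open how strongly any of them acts in this assay, and whether changing the group on the sulfonyl sulfur makes any difference there.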